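Carbonyl group in place of hydroxyalkyl on the ring nitrogen

This account rests on a few compounds, and the source may have more. Where it says the series, first, only, none or still open, it means among the compounds named here.

In an in vitro ADME assay on microsomes from liver (Homo sapiens) for metabolic stability, tested at 1 uM (a lower number here means that the compound disappears faster, a higher number that the compound lasts longer), compound 3 (`CC(C)(O)CCN1CCC(NS(=O)(=O)c2cc(S(=O)(=O)c3ccccc3)ccc2C(F)(F)F)CC1`) gives < 0.0167 h, which is a limit. Compound 1 (`O=C(c1ccc(Cl)nc1)N1CCC(NS(=O)(=O)c2cc(S(=O)(=O)c3ccccc3)ccc2C(F)(F)F)CC1`) gives > 0.5 h, also a limit. Compound 2 (`CN(C)c1ccc(C(=O)N2CCC(NS(=O)(=O)c3cc(S(=O)(=O)c4ccccc4)ccc3C(F)(F)F)CC2)cn1`) gives 0.05 h.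

Compound 4 (`O=C(CC1CCNCC1)N1CCC(NS(=O)(=O)c2cc(S(=O)(=O)c3ccccc3)ccc2C(F)(F)F)CC1`) carries ((piperidin-4-yl)methyl)carbonyl in place of 3-hydroxy-3-methylbutyl on the amine nitrogen in a ring: ((piperidin-4-yl)methyl)carbonyl in place of 3-hydroxy-3-methylbutyl on an amine nitrogen in a ring. Two measured steps make the opposite kind of exchange, a carbonyl group leaving that nitrogen and 3-hydroxy-3-methylbutyl entering: an at least 29-fold lower number from compound 1 to compound 3 (1.47 log units; beyond the scatter), which is large, and an at least 2.9-fold lower number from compound 2 to compound 3 (0.47 log units; beyond the scatter), at least modest. The carbonyl pair also spreads widely, with an at least 10-fold lower number from compound 1 to compound 2 (1.00 log units; beyond the scatter). A rise is therefore expected in this assay, with an expected size of an at least 8.9-fold higher number from compound 3 to compound 4 (0.95 log units; beyond the scatter). For compound 4 the estimated half-life is 0.15 h, with a range of 0.04 h to 0.5 h.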

Compound 4, half-life: > 0.5 h
Compound 4 ended at the assay's limit; the forecaster's own chance of this, stated with the estimate: 20%; middle value at least 3.3-fold (0.52 log units) away from the limit.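

In this assay, the new carbonyl group on the ring nitrogen gives an at least 29-fold higher number from compound 3 to compound 4 (1.47 log units; beyond the scatter), so this position tolerates a carbonyl bearing a non-aromatic (piperidin-4-yl)methyl. The carbonyl alone does not settle the outcome, since the group on the carbonyl carbon still matters: an at least 10-fold higher number from compound 2 to compound 4 (1.00 log units; beyond the scatter). Compound 1 and compound 4 both sit at the upper limit, so the step between them cannot be read: the limit of > 0.5 h in this assay, at which 2 of the 4 values shown sit.

Open, going by these compounds, is how compound 1 and compound 4 rank beyond that limit. Also open, on these data alone, is whether the piperidine amine matters, which a cyclohexyl group or a longer chain on the carbonyl carbon would address.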